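The source may report more compounds than this note shows. Statements on the series, on what has been measured and on what is new or still open speak of the compounds shown alone.

Values from a functional assay on MCF7 cells (Homo sapiens) for inhibition, read by MTT assay, with a stated time of 72 h (a lower number here means a stronger inhibitor, a higher number a weaker inhibitor), follow
Compound 1 `COc1cc(OC)c(OC)cc1/C=C/C(=O)c1cc(OC(C)=O)ccc1OC(C)=O` gives 63700 nM
Compound 2 `COc1ccc(C(=O)/C=C/c2cc(OC)c(OC)cc2OC)cc1` gives 33900 nM
Compound 3 `COc1cc(OC)c(-c2cc(=O)c3cc(Cl)ccc3o2)cc1OC` gives > 150000 nM as a limit of the assay, not a number

For the measured compounds named here, compound 2 holds one of only two true numbers here, and compound 1 lies within the usual scatter of it, so the two cannot be ranked. Compound 4 `COc1cc(OC)c(OC)cc1/C=C/C(=O)c1ccc(C)cc1` keeps the rest of compound 2 and changes one group: methyl in place of methoxy on an aromatic carbon that is, methyl in place of methoxy on an aromatic carbon, para to a large group. Going by the values given here, no measured pair shows this change, so the expectation starts from compound 2 at 33900 nM as the closest reference. No shift beyond the scatter is expected in this assay in either direction. The expected change a 1.1-fold lower number from compound 2 to compound 4 (0.03 log units; within the scatter) stays within the scatter. For compound 4 the estimate is 32000 nM with an expected range from 13000 nM to 80000 nM as its bounds.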

Compound 4, half-maximal inhibitory concentration: 33000 nM
Estimate against measurement, compound 4: 1.0-fold (0.01 log units) below, within the range that was stated.
By their numbers in this assay, from the lowest: compounds 4, 2 and 1 (each within the scatter of the next). At a limit, above all of these: compound 3.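

In this assay, for the compounds shown here, this position now has its first direct comparison, since the earlier compounds offered no pair differing in one place: methyl in place of methoxy, para to a large group, gives a 1.0-fold lower number from compound 2 to compound 4 (0.01 log units; within the scatter). The methoxy group can therefore be replaced here by methyl, which lacks its oxygen and its hydrogen-bond acceptor, without a change beyond the scatter. No measurement shown explains this result. As far as these compounds go, whether an amine, a carboxylic acid or a longer chain at this position would shift the number remains open. This single pair also cannot show whether the same replacement would behave alike on another core.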